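A few compounds are considered here, and "the series" means these few. Any claim that something is new, unique, unknown or untested is made for them only; others in the source may bear on it.

Working notes on the amide series

Three amides built on the shared core have been run in an assay on lysate for inhibition of phosphatidylcholine:ceramide cholinephosphotransferase 2 (Homo sapiens), read by HPLC, with stated times of 30 min and 2 h; a lower number here means a stronger inhibitor, a higher number a weaker inhibitor. Compound 1 `O=C(NCc1ccccc1)c1ccccc1OCc1ccccc1` gives 34200 nM. Compound 2 `O=C(NC1CCCCC1)c1ccccc1OCc1ccccc1` gives 43400 nM, the highest number of the three. Compound 3 `O=C(Nc1ccccn1)c1ccccc1OCc1ccccc1` gives 11700 nM. Between them the steps read a 1.3-fold higher number from compound 1 to compound 2 (0.10 log units; within the scatter), a 2.9-fold lower number from compound 1 to compound 3 (0.47 log units; beyond the scatter) and a 3.7-fold lower number from compound 2 to compound 3 (0.57 log units; beyond the scatter); only the two steps into compound 3 lie beyond the scatter.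

Compound 4 `O=C(Nc1cccnc1)c1ccccc1OCc1ccccc1` has not yet been measured in this assay. It differs from compound 2 by pyridin-3-yl in place of cyclohexyl on an amide-type nitrogen. The step bearing most directly on this change is a 3.7-fold lower number from compound 2 to compound 3 (0.57 log units; beyond the scatter), where a pyridin-2-yl stood in for the same cyclohexyl; a 2.9-fold lower number from compound 1 to compound 3 (0.47 log units; beyond the scatter) points the same way. Compound 4 carries pyridin-3-yl rather than pyridin-2-yl, so a modest lowering in this assay is expected, with less certainty than for a repeat of the measured step. For compound 4 the expected number is 15000 nM, within a range of 6000 nM to 40000 nM. For compound 4 this amounts to an expected step of a 2.9-fold lower number from compound 2 to compound 4 (0.46 log units; beyond the scatter).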

Compound 4, half-maximal inhibitory concentration: 3200 nM
Estimate against measurement, compound 4: 4.7-fold (0.67 log units) above, and the stated range ends above it.
By their numbers in this assay, from the lowest: compound 4; then compound 3; then compounds 1 and 2 (each within the scatter of the next).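

In this assay the two pyridine isomers are not interchangeable on the amide-type nitrogen: pyridin-3-yl in place of pyridin-2-yl gives a 3.7-fold lower number from compound 3 to compound 4 (0.56 log units; beyond the scatter), so the place of the ring nitrogen matters, and not merely the presence of an aromatic ring with one hetero atom. With pyridin-3-yl the steps away from the two non-pyridine amides become large, with a 14-fold lower number from compound 2 to compound 4 (1.13 log units; beyond the scatter) and an 11-fold lower number from compound 1 to compound 4 (1.03 log units; beyond the scatter), where the corresponding pyridin-2-yl steps were modest. Nothing at hand explains why the two isomers differ.

The compounds shown leave open where pyridin-4-yl or a plain phenyl on the same nitrogen would fall, and so how much of the lowering depends on the ring nitrogen at all. As far as these compounds go, whether the pyridin-3-yl advantage holds with other groups on the shared core also remains open.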